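A Boron-Bearing Group Replaces 4-Methoxyphenyl

The source may report more compounds than this note shows. Statements on the series, on what has been measured and on what is new or still open speak of the compounds shown alone.

- compound 1 `COc1cc(Nc2c(-c3ccc(F)cc3)nc3cnccn23)cc(OC)c1OC`: 48000 nM
- compound 2 `COc1ccc(Nc2c(-c3ccc(Cl)cc3)nc3cnccn23)cc1`: 45000 nM
- compound 3 `COc1ccc(Nc2c(-c3ccc(OC)cc3)nc3ccccn23)cc1`: 54000 nM

These values come from an ADME assay on Vero cells (Chlorocebus sabaeus) for cytotoxicity, read by MTT assay; a higher number here means that more compound is tolerated, a lower number that less compound is tolerated. In this assay, compound 3 stands at 54000 nM, within the usual scatter of both compound 1 and compound 2, so the numbers do not separate the three. No two of these compounds differ in only one place, so no single structural change can be read from them.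

Compound 4 `COc1ccc(Nc2c(-c3cccc(B(O)O)c3)nc3ccccn23)cc1` is made from compound 3 by replacing the 4-methoxyphenyl group, on an aromatic carbon of the five-membered aromatic ring with 2 nitrogen, with a group of 9 heavy atoms that includes 1 boron and 2 oxygen: a group of 9 heavy atoms (6 carbon, 1 boron, 2 oxygen; one six-membered aromatic ring of carbon only) in place of a group of 8 heavy atoms (7 carbon, 1 oxygen; one six-membered aromatic ring of carbon only), on an aromatic carbon. For the measured compounds named here, none of the measured compounds contains boron, so the data offer no direct guide to this change.

The expected step, a 1.5-fold lower number from compound 3 to compound 4 (0.19 log units; within the scatter), is a modest move towards a lower number, with real uncertainty. For compound 4 the estimated value is 35000 nM, with an expected range from 10000 nM to 80000 nM.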

Compound 4, concentration lethal to 50% of the cells: 58000 nM
Compound 4: the middle estimate sits 1.7-fold (0.22 log units) below what was measured, and the stated range covers the measured number.
By their numbers in this assay, from the lowest: compounds 2, 1, 3 and 4 (each within the scatter of the next).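

In this assay, putting the boron-bearing group in place of the 4-methoxyphenyl group gives a 1.1-fold higher number from compound 3 to compound 4 (0.03 log units; within the scatter), so the two compounds cannot be told apart. For the compounds shown here, this is the first pair here that differs in one place. It shows that, on this aromatic carbon of the five-membered aromatic ring with 2 nitrogen, a group containing boron and oxygen can stand in for 4-methoxyphenyl with a step that stays within the scatter, and no measurement at hand gives a reason for this result.

Still open, on these data alone, is whether an amine or a carboxylic acid on the same six-membered aromatic ring would also leave the number within the scatter. Also open, as far as these compounds go, is whether the same exchange would give a step of similar size on the core of compound 1.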